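This account rests on a few compounds, and the source may have more. Where it says the series, first, only, none or still open, it means among the compounds named here.

Measured so far in an assay on isolated protein for activation of cGMP-dependent protein kinase 1 (Homo sapiens), read by ADP-Glo, with stated times of 30 min and 2 h, in the presence of a further agent that is not named here; on this read-out higher numbers stand for an effect only at larger amounts of compound and lower numbers for an effect already at smaller amounts:
Compound 1, `O=C(O)C12CC(CN3CCC[C@H](O[C@H](CO)c4cc(Cl)cc(Cl)c4)[C@@H]3c3ccccc3)(C1)C2`, gives 12000 nM.
Compound 2, `OC[C@@H](O[C@H]1CCCN(Cc2nc3ccccc3[nH]2)[C@H]1c1ccccc1)c1cc(Cl)cc(Cl)c1`, gives 4700 nM.

Going by the values given here, compound 2 holds the lowest of the two numbers; the only measured step, a 2.6-fold lower number from compound 1 to compound 2 (0.41 log units; beyond the scatter), separates it from compound 1. Among the compounds with values here, that step exchanged the whole group on the ring nitrogen, and it is the sole guide available here.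

Compound 3, `O=C(O)c1ccc2nc(CN3CCC[C@H](O[C@H](CO)c4cc(Cl)cc(Cl)c4)[C@@H]3c3ccccc3)[nH]c2c1`, keeps everything of compound 2 and differs only by carboxy in place of hydrogen on an aromatic carbon. Within the data shown here, no measured pair changes this ring while leaving the rest fixed, so the measured step bears on the new change only loosely: it shows that this part of the molecule can move the number by a modest amount, but not what a carboxy on the fused aromatic ring does. Compound 1 carried a carboxy on its own, different group, and gave the higher number; that is a weak hint at most.

The expected step, a 1.2-fold lower number from compound 2 to compound 3 (0.07 log units; within the scatter), is therefore small and of uncertain direction. Compound 3 is estimated at 4000 nM, with a range from 1200 nM to 13000 nM.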

Compound 3, half-maximal effective concentration: 380 nM
Compound 3: the middle estimate sits 11-fold (1.02 log units) above what was measured; measured number below the stated range.
By their numbers in this assay, from the lowest: compound 3; then compound 2; then compound 1.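

In this assay, one small addition made a large difference: carboxy in place of hydrogen on an aromatic carbon of the fused system gives a 12-fold lower number from compound 2 to compound 3 (1.09 log units; beyond the scatter). Going by these compounds alone, this single change moves the number further than exchanging the whole group on the ring nitrogen did, which gave a 2.6-fold lower number from compound 1 to compound 2 (0.41 log units; beyond the scatter), so this aromatic carbon is a far more sensitive place than the earlier compounds could reveal. Compound 1 also carries a carboxy, on its group of 2 four-membered rings, yet the exchange of that group gives a 32-fold lower number from compound 1 to compound 3 (1.50 log units; beyond the scatter), so among these compounds a carboxy does not bring a low number on its own, and the group that carries it matters.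

The compounds shown leave open whether the carboxy must sit on this particular aromatic carbon, and whether a tetrazole, a primary amide or a methyl ester there would give a comparably low number. Nothing among the available data explains the size of this gain.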